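Chloro to fluoro exchange across two cores

A few compounds are considered here, and "the series" means these few. Any claim that something is new, unique, unknown or untested is made for them only; others in the source may bear on it.

Compound 1 `Clc1ccc(-c2n[nH]cc2N2CCCNCC2)cc1` and compound 2 `Fc1ccc(-c2n[nH]cc2N2CCCNCC2)cc1` share one core; compound 3 `Clc1ccccc1-c1n[nH]cc1N1CCNCC1` and the not yet measured compound 4 `Fc1ccccc1-c1n[nH]cc1N1CCNCC1` share another. The difference between the two cores is not broken down here. In an assay on isolated protein for binding affinity to 5-hydroxytryptamine receptor 3A (Homo sapiens) (a higher number here means a weaker inhibitor, a lower number a stronger inhibitor), compound 1 gives 498 nM and compound 2 gives 1810 nM. The change between them is fluoro in place of chloro on an aromatic carbon and it made a 3.6-fold higher number from compound 1 to compound 2 (0.56 log units; beyond the scatter). For compound 3 this assay reports only a limit, > 10000 nM. Compound 4 differs from compound 3 by fluoro in place of chloro on an aromatic carbon; this is the same kind of change as that from compound 1 to compound 2, but the place is not the same: para to a large group in the first pair, ortho to a large group in the second. Among the compounds with values here, because compound 3 sits at the limit of > 10000 nM in this assay, at which 1 of the 3 values shown sits, and the only measured step of this kind, a 3.6-fold higher number from compound 1 to compound 2 (0.56 log units; beyond the scatter), ran toward a higher number, compound 4 is expected to remain at that limit as well. The step this estimate means is a step that the limit leaves unreadable from compound 3 to compound 4. The expected value for compound 4 in this assay is 25000 nM, with a range from 8000 nM to 100000 nM.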

Compound 4, inhibition constant: 1960 nM
Compound 4: middle estimate off by 13-fold (1.11 log units), on the high side; the whole stated range lies above it.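

In this assay compound 3 is reported only as a limit and not as a number, > 10000 nM. Fluoro in place of chloro on an aromatic carbon, here ortho to a large group, gives an at least 5.1-fold lower number from compound 3 to compound 4 (0.70 log units; beyond the scatter), so neither the direction nor the size of the earlier step carried over from one core to the other: the same change on two cores in this assay, a 3.6-fold higher number (0.56 log units; beyond the scatter) from compound 1 to compound 2 and an at least 5.1-fold lower number (0.70 log units; beyond the scatter) from compound 3 to compound 4, at least 18-fold (1.26 log units) apart, beyond the scatter of two such steps Core and place of the exchange change together between the two pairs, so these steps do not show which of the two goes with the reversal, and the size of the new step is only a lower bound.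

As far as these compounds go, it remains open whether the same halogen exchange on one core, at the two places in turn, would separate place from core. Also open, from the compounds shown here alone, is how an unsubstituted aromatic ring, or a methyl or methoxy group at the same place, would compare with chloro and fluoro on either core.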